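This account rests on a few compounds, and the source may have more. Where it says the series, first, only, none or still open, it means among the compounds named here.

Values in a physicochemical assay for solubility, in phosphate buffer, measured as kinetic solubility, at pH 7.4 (a higher number here means a more soluble compound, a lower number a less soluble compound), for the series so far:
- compound 1 `Cc1oc(-c2c(Cl)cccc2C(F)(F)F)nc1CN1CCC(C(=O)NCCCN2C[C@H](C)C[C@H](C)C2)CC1` gives 65.1 ug/mL
- compound 2 `COc1cccc(OC)c1-c1nc(CN2CCC(C(=O)NCCCN3C[C@H](C)C[C@H](C)C3)CC2)c(C)o1` gives > 76 ug/mL (a limit of the assay, not a number)

Compound 2 stands at the limit of > 76 ug/mL in this assay, at which 1 of the 2 values shown sits, and has no number of its own. The next compound to be read is compound 3 `Cc1ccc(-c2nc(CN3CCC(C(=O)NCCCN4C[C@H](C)C[C@H](C)C4)CC3)c(C)o2)c(C)c1`, which has 2,4-dimethylphenyl in place of 2,6-dimethoxyphenyl on an aromatic carbon, counted as 2,4-dimethylphenyl in place of 2,6-dimethoxyphenyl on an aromatic carbon and sitting on the shared core.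

Going by the values given here, one measured step bears on this change, a swap of aryl groups at the same place: an at least 1.1-fold higher number from compound 1 to compound 2 (0.06 log units; that floor lies within the scatter) is all that is known of it. From the compounds shown here alone, its true size stays open, since one end is a limit. Compound 1, with a quite different group there, gives 65.1 ug/mL. With only this to go on, no change beyond the scatter is expected in this assay in either direction, and a reading at the limit is quite possible.

The expected step is an at least 1.1-fold lower number from compound 2 to compound 3 (0.06 log units; that floor lies within the scatter) on this estimate. For compound 3 the estimated value is 65 ug/mL with an expected range of 35 ug/mL to 85 ug/mL in this reading.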

Compound 3, solubility: > 71 ug/mL
Compound 3: no number, only a limit; the forecaster's own chance of this, stated with the estimate: 40%; middle value at least 1.0-fold (0.03 log units) away from the limit.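

In this assay compound 3 gives > 71 ug/mL, a limit of the assay and not a number. The aryl position on the shared core now carries a group of carbon only, 2,4-dimethylphenyl, and it too reads at a limit, so such a reading at this position is not confined to 2,6-dimethoxyphenyl with its two hydrogen-bond acceptors. Against the one compound with a number, the change gives an at least 1.0-fold higher number from compound 1 to compound 3 (0.03 log units; that floor lies within the scatter), and the step between the two limit compounds cannot be read.

From the compounds shown here alone, the true values of compound 2 and compound 3 stay unknown, so neither their order nor the full size of either change from compound 1 can be stated. Also open, going by these compounds, is how this assay would respond to a phenyl carrying an amine or a carboxylic acid at this position, and whether any aryl group here gives a step beyond the scatter.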